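Shared core with varied six-ring substituent: cyano to methyl

The compounds below may be only part of what the source reports. "The series", "measured", "known", "first", "only" and "open" are said of these compounds alone.

Measured so far:
compound 1 `Oc1nc2cc(F)ccc2o1` — > 50000 nM in an assay on isolated protein for inhibition of Nitric oxide synthase, inducible (Homo sapiens); on this read-out lower numbers stand for stronger inhibition and higher numbers for weaker inhibition (a limit, not a number)
compound 2 `N#Cc1ccc2oc(O)nc2c1` — 14500 nM in this assay

Compound 1 sits at a limit of this assay; its value > 50000 nM is a limit and no number. Going by the values given here, compound 2 gives 14500 nM in this assay and is the only compound with a number. Among the compounds with values here, the one further value, that of compound 1, is the limit of > 50000 nM in this assay, at which 1 of the 2 values shown sits. The measured step is an at least 3.4-fold lower number from compound 1 to compound 2 (0.53 log units; beyond the scatter).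

Compound 3 `Cc1ccc2oc(O)nc2c1` differs from compound 2 by methyl in place of cyano on an aromatic carbon. Within the data shown here, no measured step replaces a cyano by a methyl; the only one that bears on the same position, from compound 1 to compound 2, swapped fluoro for cyano and was at least modest, so the cyano is the one substituent here tied to a number below the limit. Removing it and putting methyl in its place is therefore expected to cost potency: compound 3 is expected to show a higher number than compound 2 in this assay, by a 2.4-fold higher number from compound 2 to compound 3 (0.38 log units; beyond the scatter), with the range wide and a real chance that only a limit is returned. The estimate for compound 3 is 35000 nM, between 10000 nM and 120000 nM.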

Compound 3, half-maximal inhibitory concentration: 9900 nM
Compound 3: the middle estimate sits 3.5-fold (0.55 log units) above what was measured, and the stated range ends above it.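

In this assay, methyl in place of cyano on this aromatic carbon gives a 1.5-fold lower number from compound 2 to compound 3 (0.17 log units; within the scatter), so the two groups cannot be told apart at this position, even though methyl carries no triple bond and no hydrogen-bond acceptor. Methyl in place of fluoro gives an at least 5.0-fold lower number from compound 1 to compound 3 (0.70 log units; beyond the scatter), in the same direction as cyano in place of fluoro, which gave an at least 3.4-fold lower number from compound 1 to compound 2 (0.53 log units; beyond the scatter), so a value below the limit at this position is no longer tied to cyano alone and the odd one out among the three substituents is fluoro. Compound 1 is the only compound at a limit, and its value is a limit and no number: the limit of > 50000 nM in this assay, at which 1 of the 3 values shown sits.

Still open, on these data alone, is whether an amine, a carboxylic acid or a longer chain such as propyl on this aromatic carbon would stay level with compound 2 and compound 3 or move clearly away from them. Also open, as far as these compounds go, is whether chloro or another halogen would behave like fluoro, and whether any of these changes would bring the series much further down from the values of compound 2 and compound 3 in this assay.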